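Moving the indane attachment point in a dopamine-type antagonist

The compounds below may be only part of what the source reports. "The series", "measured", "known", "first", "only" and "open" are said of these compounds alone.

Measured so far:
compound 1 `c1ccc2c(c1)CCC2CCCN1CCN(c2cccc3c2OCCO3)CC1` — 0.16 mg/kg
compound 2 `COc1cc2c(cc1OC)C(CCN1CCN(c3cccc4c3OCCO4)CC1)CC2` — 2.5 mg/kg
compound 3 `c1ccc2c(c1)CCC2CCN1CCN(c2cccc3c2OCCO3)CC1` — 0.63 mg/kg

Three compounds have been run in a functional assay on the whole organism for antagonist activity, with Rattus norvegicus as the target; a lower number here means that less compound is needed, a higher number that more compound is needed for the effect. Compound 1 gives 0.16 mg/kg, the lowest of the three numbers. Compound 3 gives 0.63 mg/kg, a higher number that lies beyond the usual scatter, and compound 2 gives 2.5 mg/kg, higher still. No two of these three differ in only one place, so none of them shows directly what a single change does.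

Compound 4 `c1ccc2c(c1)CC(CCCN1CCN(c3cccc4c3OCCO4)CC1)C2` has not been measured. It differs from compound 1 in one place: 2,3-dihydro-1H-inden-2-yl in place of 2,3-dihydro-1H-inden-1-yl on a saturated chain carbon, three bonds along the chain from an amine nitrogen in a ring. The atoms are the same; only the point where the chain joins the indane moves.

Within the data shown here, with no measured pair showing the effect of such a move, the expectation for compound 4 rests on compound 1 alone, with wide uncertainty. A modest increase from compound 1 to compound 4, a 2.5-fold higher number from compound 1 to compound 4 (0.40 log units; beyond the scatter), is expected, on the assumption that the change costs some effect but not much. Compound 4 is estimated at 0.4 mg/kg, within a range of 0.1 mg/kg to 1.6 mg/kg.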

Compound 4, minimum effective dose: 0.63 mg/kg
Beside the measured number, compound 4's estimate is 1.6-fold (0.20 log units) below it; low and high end bracket the measured number.
By their numbers in this assay, from the lowest: compound 1; then compounds 3 and 4 (each within the scatter of the next); then compound 2.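

Moving the point where the chain joins the indane, with the atoms unchanged, is not a neutral change in this assay. Among these compounds, the step is a 3.9-fold higher number from compound 1 to compound 4 (0.60 log units; beyond the scatter), so at this place on the chain 2,3-dihydro-1H-inden-1-yl gives the lower number, and this is the first direct reading of a single change, something the three earlier compounds could not provide. Nothing available here explains why the attachment point matters.

On these data alone, whether the same move would cost as much in compound 3, whose structure has a different chain, stays open. Also open, as far as these compounds go, is whether a longer chain, or a hydroxyl group on the indane of compound 1, would keep the number as low as that of compound 1.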